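Adding a methoxy group to the pendant phenyl of compound 2

The source may hold more compounds than are shown below. What is called first, only, known or untested is meant among the compounds shown, and "the series" means these compounds.

Measured so far:
- compound 1, `Cc1ccc(OCc2ccccc2)c(C/C=C/c2ccccc2/C=C/C(=O)NS(=O)(=O)c2cccs2)c1`: in an assay on isolated protein for binding affinity to prostaglandin E2 receptor EP4 subtype (Homo sapiens) (a higher number here means a weaker inhibitor, a lower number a stronger inhibitor), compound 1 gives 960 nM
- compound 2, `O=C(/C=C/c1ccccc1/C=C/Cc1ccccc1)NS(=O)(=O)c1cccs1`: in this assay compound 2 gives 1500 nM

Compound 2 has the higher of the two inhibition constants known so far; compound 1 comes closest, and the gap between the two lies within the scatter of the measurement, so the two are not distinguished by the numbers shown. Compound 3, `COc1ccc(C/C=C/c2ccccc2/C=C/C(=O)NS(=O)(=O)c2cccs2)cc1`, is not yet measured. Compared with compound 2 it carries methoxy in place of hydrogen on an aromatic carbon. For the measured compounds named here, no step between two measured compounds follows exactly this change, so the size of the step has to be guessed. Given that the differently substituted pendant phenyl of compound 1 gives 960 nM in this assay, close to the value of compound 2, only a small step is expected, of no clear direction beyond the scatter. For compound 3 the expected value in this assay is 1100 nM, within 450 nM to 2700 nM, which means an expected step of a 1.4-fold lower number from compound 2 to compound 3 (0.13 log units; within the scatter).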

Compound 3, inhibition constant: 1000 nM
Beside the measured number, compound 3's estimate is 1.1-fold (0.04 log units) above it; the range from low to high includes it.
By their numbers in this assay, from the lowest: compounds 1, 3 and 2 (each within the scatter of the next).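

In this assay, methoxy in place of hydrogen on the pendant phenyl, para to a large group, gives a 1.5-fold lower number from compound 2 to compound 3 (0.18 log units; within the scatter), so the numbers do not separate the 4-methoxyphenyl group from the plain phenyl. This is the only step among the compounds shown that reads a single change, since compound 1 differs from compound 2 in more than one place and could only hint at how this ring tolerates substitution. Nothing measured alongside these values speaks to what lies behind this result.

From the compounds shown here alone, it remains open whether a group of another kind at this carbon, such as an amine, a carboxylic acid or a longer chain like butoxy, would give a step beyond the scatter. The compounds shown also leave open how a methoxy group alone would read on the other carbons of this ring.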